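Swapping the trimethoxyphenyl ring for a chlorophenyl in compound 2

The compounds below may be only part of what the source reports. "The series", "measured", "known", "first", "only" and "open" are said of these compounds alone.

Measured compounds:
compound 1 `COc1cc(-c2nc(SCc3cn(CC(=O)NC(=O)Nc4ccccn4)nn3)nc(Nc3ccc(C(C)C)cc3)c2C#N)cc(OC)c1OC`: 35500 nM
compound 2 `COc1cc(-c2nc(SCc3cn(CC(=O)NC(=O)Nc4ccccn4)nn3)nc(Nc3ccc(C)cc3)c2C#N)cc(OC)c1OC`: 7030 nM
compound 3 `COc1cc(-c2nc(SCc3cn(CC(=O)NC(=O)Nc4ccccn4)nn3)nc(Nc3cccc(Cl)c3)c2C#N)cc(OC)c1OC`: 15400 nM

All three compounds share one core and were tested in a functional assay on MGC-803 cells (Homo sapiens) for inhibition, read by MTT assay, with a stated time of 72 h; a higher number here means a weaker inhibitor, a lower number a stronger inhibitor. Compound 2 gives the lowest number of the three: going from the isopropyl to the methyl on the aromatic carbon gave a 5.0-fold lower number from compound 1 to compound 2 (0.70 log units; beyond the scatter), and the chlorophenyl variant compound 3 sits between them, with a 2.2-fold higher number from compound 2 to compound 3 (0.34 log units; beyond the scatter) and a 2.3-fold lower number from compound 1 to compound 3 (0.36 log units; beyond the scatter). Among the compounds with values here, every measured step so far therefore changes only the substituted anilino part, and each of them was modest.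

Compound 4 `Cc1ccc(Nc2nc(SCc3cn(CC(=O)NC(=O)Nc4ccccn4)nn3)nc(-c3ccc(Cl)cc3)c2C#N)cc1` differs from compound 2 elsewhere: 4-chlorophenyl in place of 3,4,5-trimethoxyphenyl on an aromatic carbon. Within the data shown here, none of the measured steps touches this part of the molecule, so no measured step bears on it directly. What the measured series does show is that a single ring change in this core moved the number by a modest amount in either direction. The same size of step seems the most reasonable expectation for this assay here, while the direction stays uncertain; removing the three methoxy groups is a larger change than any measured one, so the range is kept wide.

The estimate for compound 4 is 14000 nM, between 4000 nM and 50000 nM, which is an expected step of a 2.0-fold higher number from compound 2 to compound 4 (0.30 log units; within the scatter).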

Compound 4, half-maximal inhibitory concentration: 24000 nM
Estimate against measurement, compound 4: 1.7-fold (0.23 log units) below, and the stated range covers the measured number.
By their numbers in this assay, from the lowest: compound 2; then compounds 3, 4 and 1 (each within the scatter of the next, the first and the last beyond it).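

In this assay, within the data shown here, the aryl group next to the ring nitrogen, which no earlier step touched, also matters: 4-chlorophenyl in place of 3,4,5-trimethoxyphenyl gives a 3.4-fold higher number from compound 2 to compound 4 (0.53 log units; beyond the scatter). This one swap changes several things at once, going from 12 heavy atoms to 7, losing 3 hydrogen-bond acceptors and bringing in a chlorine, so the step cannot show whether losing the methoxy groups or gaining the chlorine moves the number. Nothing available explains the rise in the number, so the step remains an observation without a known cause.

The compounds shown leave open how a plain phenyl or a phenyl carrying a single methoxy group would behave at this position, and either could help separate the two parts of the swap. Going by these compounds, it also remains open whether an amine or a carboxylic acid on this ring would shift the number, and whether the same swap would give a similar step alongside the 4-isopropylphenyl or 3-chlorophenyl group on the amino nitrogen.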